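Halogenated phenyl series: from compound 2 to compound 3

A few compounds are considered here, and "the series" means these few. Any claim that something is new, unique, unknown or untested is made for them only; others in the source may bear on it.

In a functional assay on K562 cells (Homo sapiens) for antiproliferative activity, with a stated time of 72 h (a lower number here means a stronger inhibitor, a higher number a weaker inhibitor), compound 2 (`OC[C@H]1O[C@@H](n2cnc3c(NCc4ccc(F)cc4F)ncnc32)[C@H](O)[C@@H]1O`) gives 9600 nM as the lower of two numbers, and compound 1 (`OC[C@H]1O[C@@H](n2cnc3c(NCc4ccc(Br)cc4)ncnc32)[C@H](O)[C@@H]1O`) gives 68200 nM as the higher. Compound 3 (`OC[C@H]1O[C@@H](n2cnc3c(NCc4c(F)ccc(F)c4F)ncnc32)[C@H](O)[C@@H]1O`) has 2,3,6-trifluorophenyl in place of 2,4-difluorophenyl on a saturated chain carbon bound to a nitrogen on an aromatic ring on the same saturated chain carbon. Going by the values given here, only one measured step bears on this change: a 7.1-fold lower number from compound 1 to compound 2 (0.85 log units; beyond the scatter) on exchanging 4-bromophenyl for 2,4-difluorophenyl. Among the compounds with values here, no measured step links two fluorinated groups, so no shift beyond the scatter is expected in this assay. The expected change is a 1.1-fold higher number from compound 2 to compound 3 (0.06 log units; within the scatter) as a working figure. Compound 3 is estimated at 11000 nM within a range of 4000 nM to 30000 nM for now.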

Compound 3, half-maximal inhibitory concentration: > 166000 nM
Compound 3 was reported as a limit (the forecaster's own chance of this, stated with the estimate: 8%); middle value at least 15-fold (1.17 log units) away from the limit.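

In this assay, fluorinated groups on the saturated chain carbon bound to a nitrogen on an aromatic ring are not interchangeable: 2,3,6-trifluorophenyl in place of 2,4-difluorophenyl gives an at least 17-fold higher number from compound 2 to compound 3 (1.23 log units; beyond the scatter). The same group also compares poorly with 4-bromophenyl, with an at least 2.4-fold higher number from compound 1 to compound 3 (0.38 log units; beyond the scatter), so fluorine on the phenyl does not by itself give the lower number seen with 2,4-difluorophenyl. Compound 3 is reported only as a limit, not a number: the limit of > 166000 nM in this assay, at which 1 of the 3 values shown sits.

The compounds shown do not separate the added fluorine from its arrangement on the phenyl. As far as these compounds go, how a methoxy group on the phenyl would stand also remains open.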